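The source may hold more compounds than are shown below. What is called first, only, known or untested is meant among the compounds shown, and "the series" means these compounds.

Measured so far:
compound 1, `CCCc1nc(C(C)(C)O)c(C(=O)O)n1Cc1ccc(-c2ccccc2C(=O)O)cc1`: 50%
compound 2, `CCCc1nc(C(C)(C)O)c(C(=O)OCOC(=O)C(C)(C)C)n1Cc1ccc(-c2ccccc2C(=O)O)cc1`: 52%
compound 3, `CCCc1nc(C(C)(C)O)c(C(=O)OC2OC(=O)c3ccccc32)n1Cc1ccc(-c2ccccc2C(=O)O)cc1`: 73%

In a functional assay on the whole organism for inhibition, with Rattus norvegicus as the target, with a stated time of 1 h, at a dose of 1 mg/kg (on this read-out higher numbers stand for more inhibition at the one dose given (going by the name of the read-out) and lower numbers for less inhibition), compound 1 has the smallest of the three numbers, but the gap a number 2 percentage points higher from compound 1 to compound 2 (within the scatter) is within the scatter, so compound 1 and compound 2 cannot be told apart, while the gap a number 23 percentage points higher from compound 1 to compound 3 (beyond the scatter) is beyond it. Compound 4, `CCCc1nc(C(C)(C)O)c(C(=O)O)n1Cc1ccc(-c2ccccc2C(=O)OCOC(=O)C(C)(C)C)cc1`, differs from compound 1 in one place: (((tert-butyl)carbonyl)oxy)methyl in place of hydrogen on an oxygen next to a carbonyl group. For the measured compounds named here, the same group entering on the other oxygen next to a carbonyl group gave the step of a number 2 percentage points higher from compound 1 to compound 2 (within the scatter), which is the only measured step that resembles this change and it stayed within the scatter. Going by the values given here, no step therefore points beyond the scatter, and the expected step is a number 2 percentage points higher from compound 1 to compound 4 (within the scatter). Compound 4 is estimated at 52%, with a range from 35% to 70%.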

Compound 4, a percentage reported as inhibition, in the whole organism at one dose (the size of the read-out at that dose, not a potency): 20%
For compound 4 the middle estimate is 32 percentage points above the measured one; the whole stated range lies above it.
By their numbers in this assay, from the lowest: compound 4; then compounds 1 and 2 (each within the scatter of the next); then compound 3.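

With (((tert-butyl)carbonyl)oxy)methyl on this oxygen next to a carbonyl group, the result is a number 30 percentage points lower from compound 1 to compound 4 (beyond the scatter), so this change can lower the inhibition seen at this dose. The same group on the other such oxygen gave a number 2 percentage points higher from compound 1 to compound 2 (within the scatter), so the outcome depends on which of the two carboxy groups carries it. Nothing shown here gives a measured reason for this difference. On these data alone, whether a small methyl group on this oxygen would also lower the number remains open. So does the effect of replacing this carboxy group with an amide.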